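The compounds below may be only part of what the source reports. "The series", "measured", "known", "first", "only" and "open" are said of these compounds alone.

Measured in a functional assay on BMEC cells (Bos taurus) for antiproliferative activity; a lower number here means a stronger inhibitor, a higher number a weaker inhibitor:
- compound 1 `COc1cc(/C=C\Cc2cc(OC)c3ccoc3c2)cc(OC)c1OC`: 7500 nM
- compound 2 `COc1cc(/C=C\c2ccc3cc[nH]c3c2)cc(OC)c1OC`: 28 nM

Compound 2 has the lower number of the two, and its gap to compound 1 lies beyond the scatter. The next compound is compound 3 `COc1cc(/C=C/c2ccc3cc[nH]c3c2)cc(OC)c1OC`, with the same atoms and bonds as compound 2: the two compounds have the same atoms and bonds and differ only in configuration as drawn: 1 of 1 stereo elements differ; a double bond is drawn Z in compound 2 and E in compound 3. Going by the values given here, no measured pair isolates such a change, so its size is an expectation only. A weaker compound is expected in this assay, with a higher number well beyond the scatter. The estimated step is a 54-fold higher number from compound 2 to compound 3 (1.73 log units; beyond the scatter). The expected value for compound 3 is 1500 nM, with an estimated range from 200 nM to 10000 nM.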

Compound 3, half-maximal inhibitory concentration: 1900 nM
Estimate against measurement, compound 3: 1.3-fold (0.10 log units) below; the measured number falls inside the stated range.
By their numbers in this assay, from the lowest: compound 2; then compound 3; then compound 1.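

In this assay, inverting the double bond alone gives a large change, a 68-fold higher number from compound 2 to compound 3 (1.83 log units; beyond the scatter). Going by these compounds alone, this is the first pair that isolates a single change, and the Z configuration carries the lower number. With nothing else changing, the step can be assigned to configuration alone: the fact that compounds 2 and 3 differ only in the configuration as drawn

Within the data shown here, open is whether the Z over E order holds on a different core, since only this one pair shows it. Also open, as far as these compounds go, is whether an amine or a carboxylic acid on the shared core would preserve the number of compound 2.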